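The source may report more compounds than this note shows. Statements on the series, on what has been measured and on what is new or still open speak of the compounds shown alone.

The measured compounds and their numbers in a functional assay on BJAB cells (Homo sapiens) for antiproliferative activity, with a stated time of 4 days; on this read-out lower numbers stand for an effect already at smaller amounts and higher numbers for an effect only at larger amounts of compound:

Compound 1 `Cc1nn(-c2nc(-c3ccc(Cl)c(Cl)c3)c(SC(C)C)s2)c(C(=O)O)c1-c1cnn(C)c1` gives 6800 nM.
Compound 2 `Cc1nn(-c2nc(-c3ccc(Cl)c(Cl)c3)c(SC(C)C)s2)c(C(=O)O)c1-c1cncc(C#N)c1` gives 20000 nM.
Compound 3 `Cc1nn(-c2nc(-c3ccc(Cl)c(Cl)c3)c(SC(C)C)s2)c(C(=O)O)c1-c1ccccc1[N+](=O)[O-]` gives 4700 nM.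

Among these three, compound 1 holds the second highest number. Compound 3 sits closest to it, and compound 2 lies furthest from it. The two steps out of compound 1 point in different directions: one was a 2.9-fold higher number from compound 1 to compound 2 (0.47 log units; beyond the scatter), the other 1.4-fold lower number from compound 1 to compound 3 (0.16 log units; within the scatter). Between the other two there was a 4.3-fold lower number from compound 2 to compound 3 (0.63 log units; beyond the scatter).

Compound 4 `Cc1cc(-c2c(C)nn(-c3nc(-c4ccc(Cl)c(Cl)c4)c(SC(C)C)s3)c2C(=O)O)cc(C)n1` has not yet been measured in this assay. It differs from compound 1 in one place: 2,6-dimethylpyridin-4-yl in place of 1-methyl-1H-pyrazol-4-yl on an aromatic carbon. Both measured steps from compound 1 exchanged the same 1-methyl-1H-pyrazol-4-yl for a six-membered aromatic ring, as this step does. One of them, to a six-membered ring with one nitrogen, was a modest rise; the other, to 2-nitrophenyl, stayed within the scatter. For compound 4 a small rise is therefore expected, and the step is estimated as a 1.3-fold higher number from compound 1 to compound 4 (0.12 log units; within the scatter). In this assay compound 4 is expected to give about 9000 nM. For compound 4 the estimated range runs from 3500 nM to 23000 nM.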

Compound 4, half-maximal effective concentration: 580 nM
Compound 4: middle estimate off by 16-fold (1.19 log units), on the high side; the whole stated range lies above it.
By their numbers in this assay, from the lowest: compound 4; then compounds 3 and 1 (each within the scatter of the next); then compound 2.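

At this position, on an aromatic carbon of the shared core, six-membered aromatic rings do not behave alike in this assay: 2,6-dimethylpyridin-4-yl gives a 12-fold lower number from compound 1 to compound 4 (1.07 log units; beyond the scatter), whereas the earlier exchanges of 1-methyl-1H-pyrazol-4-yl gave only a modest rise or a change within the scatter. The same group also separates clearly from both earlier six-membered replacements, with an 8.1-fold lower number from compound 3 to compound 4 (0.91 log units; beyond the scatter) and a 34-fold lower number from compound 2 to compound 4 (1.54 log units; beyond the scatter), so a ring nitrogen alone does not set the direction, as compound 2 also carries a ring with one nitrogen yet has the highest number of the four. No measured property shown here accounts for this difference.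

The compounds shown do not separate the contribution of the two methyl groups from that of the ring nitrogen, which a plain pyridin-4-yl or a dimethylphenyl group would address. Going by these compounds, it also remains open whether ethyl groups in place of those methyl groups, or an amine on the same ring, would keep the number as low as that of compound 4 in this assay.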